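The source may report more compounds than this note shows. Statements on the series, on what has been measured and on what is new or still open speak of the compounds shown alone.

In an ADME assay on the whole organism with Oryza sativa as the target, tested at 0.1 uM (a higher number here means a weaker effect of the compound at the concentration tested, a lower number a stronger effect), compound 3 `CCCCc1ccc(NC(=O)N[C@@H](C)c2ccccc2)cc1` gives 98%, the second highest of the three numbers measured. Its nearest neighbour is compound 2 `CCCCc1ccc(NC(=O)N[C@H](C)c2ccccc2)cc1`, which gives 100%; the step of a number 2 percentage points lower from compound 2 to compound 3 (within the scatter) stays within the scatter, which fits (the fact that compounds 2 and 3 differ only in the configuration as drawn). Compound 1 `CC(C)c1cccc(NC(=O)N[C@H](C)c2ccccc2)c1` gives 74%, a lower number.

Compound 4 `C[C@H](NC(=O)Nc1ccc(F)cc1)c1ccccc1` has not yet been measured. The change from compound 3 is fluoro in place of butyl on an aromatic carbon. Among the compounds with values here, none of the measured steps covers such an exchange: the only measured step concerns configuration alone and was small, so it carries no information about swapping groups on the ring. For compound 4 an estimate of about 85% is made, with a range from 55% to 100%. This estimate means an expected step of a number 13 percentage points lower from compound 3 to compound 4 (beyond the scatter), which is not clearly beyond the scatter.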

Compound 4, a percentage reported as activity, at one concentration (the size of the read-out at that concentration, not a potency): 96%
Compound 4: the middle estimate sits 11 percentage points below what was measured, within the range that was stated.
By their numbers in this assay, from the lowest: compound 1; then compounds 4, 3 and 2 (each within the scatter of the next).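

In this assay, putting fluoro in place of butyl on this aromatic carbon, para to a large group, gives a number 2 percentage points lower from compound 3 to compound 4 (within the scatter). The earlier compounds shown here showed only a change of configuration, whereas this shows that a four-carbon chain and a single fluorine read alike at this place. Within the data shown here, nothing measured so far gives a reason for this. From the compounds shown here alone, whether an amine, a carboxylic acid or a longer chain at this place would also read alike stays open. So does whether this exchange would read the same on the core of compound 1.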